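The compounds below may be only part of what the source reports. "The series", "measured", "known", "first", "only" and "open" are said of these compounds alone.

Measured compounds:
compound 1 `CC(C)[C@H](NC(=O)COc1cccc2ccccc12)C(=O)N[C@@H](CC(=O)O)C(=O)COc1cccc(C(F)(F)F)c1` — > 100000 nM in a functional assay on Jurkat cells (Homo sapiens); on this read-out higher numbers stand for weaker inhibition and lower numbers for stronger inhibition (a limit of the assay)
compound 2 `CC(C)[C@H](NC(=O)COc1cccc2ccccc12)C(=O)N[C@@H](CC(=O)O)C(=O)COc1c(F)cccc1F` — 2040 nM in this assay
compound 3 `CC(C)[C@H](NC(=O)COc1cccc2ccccc12)C(=O)N[C@@H](CC(=O)O)C(=O)COc1ccc(F)c(F)c1` — > 100000 nM in this assay (a limit of the assay)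

In this assay compound 1 gives > 100000 nM, which is a limit of the assay and not a number. Compound 3 also sits at a limit, giving > 100000 nM in this assay. Compound 2 alone gives a number, 2040 nM in this assay; the other two values sit at the limit of > 100000 nM in this assay, at which 2 of the 3 values shown sit. The step of an at least 49-fold lower number from compound 1 to compound 2 (1.69 log units; beyond the scatter) is large, as is an at least 49-fold higher number from compound 2 to compound 3 (1.69 log units; beyond the scatter), whereas a step that the two limits leave unreadable from compound 1 to compound 3 cannot be read from two limits.

Compound 4 `CC(C)[C@H](NC(=O)COc1cccc2ccccc12)C(=O)N[C@@H](CC(=O)O)C(=O)COc1c(Cl)cccc1Cl` is not yet measured. It differs from compound 1 by 2,6-dichlorophenyl in place of 3-(trifluoromethyl)phenyl on an oxygen on a saturated carbon. Within the data shown here, the step that bears on it is the one from compound 1 to compound 2, where 2,6-difluorophenyl produced a large fall, while 3,4-difluorophenyl in compound 3 stayed at the limit. Since 2,6-dichlorophenyl resembles 2,6-difluorophenyl, a large downward step is expected, an at least 66-fold lower number from compound 1 to compound 4 (1.82 log units; beyond the scatter). Compound 4 is therefore estimated at 1500 nM in this assay, between 300 nM and 10000 nM.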

Compound 4, half-maximal inhibitory concentration: 3000 nM
Compound 4: middle estimate off by 2.0-fold (0.30 log units), on the low side; the measured number falls inside the stated range.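

In this assay, 2,6-dichlorophenyl brings an at least 33-fold lower number from compound 1 to compound 4 (1.52 log units; beyond the scatter) and also an at least 33-fold lower number from compound 3 to compound 4 (1.52 log units; beyond the scatter), so a measurable value at this position is no longer tied to 2,6-difluorophenyl alone. Between those two groups the result is a 1.5-fold higher number from compound 2 to compound 4 (0.17 log units; within the scatter), so chlorine and fluorine in this pattern cannot be told apart on this read-out. Across the four compounds, only 2,6-difluorophenyl and 2,6-dichlorophenyl give numbers, while 3-(trifluoromethyl)phenyl in compound 1 and 3,4-difluorophenyl in compound 3 remain at a limit of the assay: the limit of > 100000 nM in this assay, at which 2 of the 4 values shown sit.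

The compounds shown leave open whether 2-fluorophenyl, plain phenyl or 2,6-dimethylphenyl, which has no halogen, would also give a number on this read-out. They also leave open how far compound 1 and compound 3 lie past their limits, so the step between those two cannot be read.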